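The source may hold more compounds than are shown below. What is called first, only, known or untested is meant among the compounds shown, and "the series" means these compounds.

Going by the values given here, compound 3 `CN(C)CCCCOC(=O)Nc1ccc(Cn2nc(-c3cccc(C#N)c3)c3ccccc3c2=O)cc1` gives 17200 nM in an ADME assay on Huh-7 cells (Homo sapiens) for cytotoxicity, read by MTT assay, with a stated time of 48 h (on this read-out lower numbers stand for higher toxicity in this test and higher numbers for lower toxicity in this test), the second highest of the three numbers measured so far. Compound 2 `CN(C)CCCCOC(=O)Nc1ccc(Cn2nc(-c3ccccc3)c3ccccc3c2=O)cc1` stands nearest to it, with compound 2 giving 16000 nM, and compound 1 `CN(C)CCCCOC(=O)Nc1ccc(Cn2nc(-c3cncnc3)c3ccccc3c2=O)cc1` stands furthest, with compound 1 giving 65300 nM. The steps between these three are a 4.1-fold lower number from compound 1 to compound 2 (0.61 log units; beyond the scatter), a 3.8-fold lower number from compound 1 to compound 3 (0.58 log units; beyond the scatter) and a 1.1-fold higher number from compound 2 to compound 3 (0.03 log units; within the scatter).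

Compound 4 `COc1ccccc1-c1nn(Cc2ccc(NC(=O)OCCCCN(C)C)cc2)c(=O)c2ccccc12` differs from compound 3 in one place: 2-methoxyphenyl in place of 3-cyanophenyl on an aromatic carbon. Among the compounds with values here, the step that bears most on this change is the one from compound 2 to compound 3, which also exchanged one substituent pattern on a six-membered aromatic ring of carbon only for another and stayed within the scatter. The two larger steps both set phenyl or 3-cyanophenyl in place of pyrimidin-5-yl, an exchange of the ring itself that does not occur here. A step within the scatter in this assay is therefore expected, a 1.0-fold lower number from compound 3 to compound 4 (0.01 log units; within the scatter). Compound 4 is estimated at 17000 nM, with a range from 8000 nM to 40000 nM.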

Compound 4, half-maximal cytotoxic concentration: 44800 nM
Compound 4: the middle estimate sits 2.6-fold (0.42 log units) below what was measured; measured number above the stated range.
By their numbers in this assay, from the lowest: compounds 2 and 3 (each within the scatter of the next); then compounds 4 and 1 (each within the scatter of the next).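

In this assay this position proved responsive to a change among six-membered aromatic rings of carbon only, which the cyano exchange had not shown: there is a 2.8-fold higher number from compound 2 to compound 4 (0.45 log units; beyond the scatter) for methoxy in place of hydrogen, and a 2.6-fold higher number from compound 3 to compound 4 (0.42 log units; beyond the scatter) for 2-methoxyphenyl in place of 3-cyanophenyl. Pyrimidin-5-yl is thus no longer the only group here that stands apart from phenyl, and with a 1.5-fold lower number from compound 1 to compound 4 (0.16 log units; within the scatter) the two cannot be told apart in this test. No measurement of any property of these groups is at hand to account for these steps.

From the compounds shown here alone, whether the steps follow from the methoxy group itself or from where it sits on the phenyl ring stays open. How an amine, a hydroxy group or a longer alkoxy chain would read at this place is also an open question.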